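Swapping bromo for methoxy on compound 3

This account rests on a few compounds, and the source may have more. Where it says the series, first, only, none or still open, it means among the compounds named here.

Values in a functional assay on SK-OV-3 cells (Homo sapiens) for antiproliferative activity, read by MTT assay, with a stated time of 72 h (a lower number here means a stronger inhibitor, a higher number a weaker inhibitor), so far
compound 1 `O=C(CCc1cccc2c1B(O)OC2)NC1CCCCC1` gives > 100000 nM (a limit)
compound 2 `O=C(CCc1cccc2c1B(O)OC2)Nc1nccs1` gives > 100000 nM (a limit)
compound 3 `O=C(CCc1cccc2c1B(O)OC2)Nc1ccc(Br)cc1` gives 9200 nM

Compound 3 is the only one of the three with an actual number (9200 nM). The entries of compound 1 and compound 2 are limits, not numbers. Compound 4 `COc1ccc(NC(=O)CCc2cccc3c2B(O)OC3)cc1` differs from compound 3 in one place (methoxy in place of bromo on an aromatic carbon), with methoxy in place of bromo on an aromatic carbon. The nearest measured steps are large (an at least 10-fold lower number from compound 1 to compound 3 (1.03 log units; beyond the scatter) and an at least 10-fold lower number from compound 2 to compound 3 (1.03 log units; beyond the scatter)), but each replaces the whole group on the amide-type nitrogen, and neither tests the bromo alone. Compound 4 keeps the rest of that group, so in this assay a much smaller step is expected, about the size of the scatter and leaning towards a higher number. The expected step (a 1.5-fold higher number from compound 3 to compound 4 (0.18 log units; within the scatter)) stays modest. The estimate for compound 4 is 14000 nM (range 5000 nM to 50000 nM).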

Compound 4, half-maximal inhibitory concentration: 900 nM
For compound 4 the middle estimate is 16-fold (1.19 log units) above the measured one; measured number outside the range, below it.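

In this assay, changing only the group on the aromatic ring gives a 10-fold lower number from compound 3 to compound 4 (1.01 log units; beyond the scatter). This position therefore matters on its own, apart from the swaps of the whole group on the amide-type nitrogen. It is also the first step here between two actual numbers, not against a limit: the limit of > 100000 nM in this assay, at which 2 of the 4 values shown sit.

The compounds shown leave open whether this gain belongs to methoxy itself or simply to the loss of bromo. An ethoxy, a hydroxy or an amine at the same position would help to separate the two.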